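From iodo to methoxy in a growth-inhibition series

This account rests on a few compounds, and the source may have more. Where it says the series, first, only, none or still open, it means among the compounds named here.

Compound 1 `NC(=O)c1cc(Cl)ccc1NC(=O)COc1ccccc1`: 2210 nM
Compound 2 `NC(=O)c1cc(I)ccc1NC(=O)COc1ccccc1`: 389 nM

In a functional assay on M14 cells (Homo sapiens) for inhibition (a higher number here means a weaker inhibitor of growth, a lower number a stronger inhibitor of growth), compound 2 holds the lower of the two numbers, at 389 nM. Compound 3 `COc1ccc(NC(=O)COc2ccccc2)c(C(N)=O)c1` differs from it as follows: methoxy in place of iodo on an aromatic carbon. Among the measured compounds shown here, only one measured step bears on this place, a 5.7-fold lower number from compound 1 to compound 2 (0.75 log units; beyond the scatter), where iodo replaced chloro. For the measured compounds named here, no methoxy analogue has been measured, so the size is uncertain, but losing the iodo is expected to give back a similar amount. A step of about that size towards a higher number is expected, a 5.7-fold higher number from compound 2 to compound 3 (0.75 log units; beyond the scatter). For compound 3 the estimated value is 2200 nM, with an expected range of 700 nM to 7000 nM.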

Compound 3, concentration for 50% growth inhibition: 514 nM
Estimate against measurement, compound 3: 4.3-fold (0.63 log units) above; the whole stated range lies above it.
By their numbers in this assay, from the lowest: compounds 2 and 3 (each within the scatter of the next); then compound 1.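

On the aromatic carbon para to a large group, the low number is not tied to iodo: methoxy gives a 1.3-fold higher number from compound 2 to compound 3 (0.12 log units; within the scatter), so compound 2 and compound 3 cannot be told apart. Methoxy also stands clear of chloro, with a 4.3-fold lower number from compound 1 to compound 3 (0.63 log units; beyond the scatter), which makes chloro the group that differs among these three. No measurement shown accounts for this.

From the compounds shown here alone, it remains open whether an amine, a hydroxyl or a longer chain such as ethoxy at this place would stay with compound 2 and compound 3 or fall back towards compound 1.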